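The source may report more compounds than this note shows. Statements on the series, on what has been measured and on what is new or still open speak of the compounds shown alone.

Measured compounds:
Compound 1, `CCOc1nccnc1Nc1cccc(C)n1`, gives 497 nM in an assay on Ltk cells with metabotropic glutamate receptor 5 (Homo sapiens) as the target, read by fluorescence and calcium flux; a lower number here means a stronger inhibitor, a higher number a weaker inhibitor.
Compound 2, `CCOc1c(C)ccnc1Nc1cccc(C)n1`, gives 2700 nM in this assay.
Compound 3, `CCOc1cc(C#N)cnc1Nc1cccc(C)n1`, gives 46 nM in this assay.

Compound 3 has the lowest number of the three and is the strongest inhibitor among them: compound 1 stands well beyond the scatter above it, and compound 2 stands further away still. Going by the values given here, no two of the measured compounds differ in only one place, so no measured step is available to show how a single change shifts the number.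

Compound 4, `CCOc1cc(-c2cccnc2)cnc1Nc1cccc(C)n1`, has not yet been measured. Against compound 3 it shows one change: pyridin-3-yl in place of cyano on an aromatic carbon. A small linear group thus makes way for a six-membered aromatic ring on the shared core.

Among the compounds with values here, no measured pair here shows what such an exchange does, so the expectation leans on compound 3 and its 46 nM as the starting point. The step of a 2.0-fold higher number from compound 3 to compound 4 (0.29 log units; within the scatter) is expected to be small, drifting toward a slightly higher number but hardly beyond the scatter. For compound 4 the expected value in this assay is 90 nM, with a likely range from 20 nM to 400 nM.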

Compound 4, half-maximal inhibitory concentration: 12 nM
Compound 4: the middle estimate sits 7.5-fold (0.88 log units) above what was measured; measured number below the stated range.
By their numbers in this assay, from the lowest: compound 4; then compound 3; then compound 1; then compound 2.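

In this assay, the exchange of cyano for pyridin-3-yl gives a 3.8-fold lower number from compound 3 to compound 4 (0.58 log units; beyond the scatter), a step beyond the usual scatter, so this aromatic carbon, two atoms from the ring nitrogen, takes a group with more heavy atoms and a six-membered aromatic ring of its own without any loss of strength. The two groups match in their counts of hydrogen-bond donors and acceptors, and neither carries a net charge, so these counts do not separate them and cannot by themselves account for the difference. Nothing measured here gives a reason for this gain in strength.

The compounds shown leave open whether the ring nitrogen of the pyridin-3-yl group matters, a question that phenyl, the same ring without that nitrogen, or pyridin-4-yl, with the nitrogen moved, could address at this position. Also open, on these data alone, is how a non-aromatic group, such as an amine or a carboxylic acid, would fare here, and whether the same exchange would give a similar step on a different core.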